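The source may hold more compounds than are shown below. What is called first, only, known or untested is meant among the compounds shown, and "the series" means these compounds.

Compound 3 `NS(=O)(=O)c1ccc(-c2cc(Nc3ccc(OC(F)(F)F)cc3)ncn2)cc1` was tested in an ADME assay on BaF3 cells (Mus musculus) for cytotoxicity (a higher number here means that more compound is needed for the effect, a lower number that less compound is needed), and gave > 10000 nM, which is a limit of the assay rather than a number. Compound 1 `CC(C)Cn1cc(-c2cc(Nc3ccc(OC(F)(F)F)cc3)ncn2)cn1` likewise gave > 10000 nM in this assay, again only a limit. Among the compounds with values here, compound 2 `FC(F)(F)Oc1ccc(Nc2cc(-c3cccc4[nH]ccc34)ncn2)cc1` gave 3790 nM in this assay; the step of an at least 2.6-fold lower number from compound 1 to compound 2 (0.42 log units; beyond the scatter) is the only measured step, and it concerns a different part of the molecule. Two of the three results sit at the limit of > 10000 nM in this assay, at which 2 of the 3 values shown sit. Compound 4 `NC(=O)c1ccc(-c2cc(Nc3ccc(OC(F)(F)F)cc3)ncn2)cc1` differs from compound 3 in one place: carbamoyl in place of sulfamoyl on an aromatic carbon. Within the data shown here, no measured step bears on this exchange, so no change beyond the scatter is expected in this assay, with compound 4 expected at 10000 nM (range 5000 nM to 30000 nM). The step that this estimate means is expected to be a number no higher from compound 3 to compound 4 (the limit leaves the size open).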

Compound 4, half-maximal effective concentration: > 10000 nM
Compound 4: a limit, no number; the forecaster's own chance of this, stated with the estimate: 70%; the middle value sits exactly at the limit.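

In this assay, carbamoyl in place of sulfamoyl on the aromatic ring leaves the result at the limit of the assay, and the steps from compound 3 and from compound 1 to compound 4 cannot be read, with limits at both ends. Within the data shown here, the one readable new step is an at least 2.6-fold higher number from compound 2 to compound 4 (0.42 log units; beyond the scatter), with 4-carbamoylphenyl in place of 1H-indol-4-yl. Compound 2 remains the only compound with a number: the limit of > 10000 nM in this assay, at which 3 of the 4 values shown sit.

As far as these compounds go, how far sulfamoyl and carbamoyl truly lie apart stays open. So does whether a carboxylic acid or an amine in the same place would bring a number under the limit.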